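The source may hold more compounds than are shown below. What is called first, only, known or untested is meant among the compounds shown, and "the series" means these compounds.

Across the series, compound 1 (`Cc1cc(C(N)=O)nn1Cc1cc(Cl)ccc1OCc1ccccc1`) gives 3.7 in a physicochemical assay for lipophilicity, at pH 7.4; on this read-out lower numbers stand for lower lipophilicity and higher numbers for higher lipophilicity. Compound 2 (`Cc1cc(C(N)=O)nn1Cc1cc(Cl)ccc1OCC(C)C`) gives 3.1 in this assay, and the step is a number 0.60 log units lower from compound 1 to compound 2 (beyond the scatter).

Compound 3 (`Cc1cc(NC(=O)C2CCCCC2)nn1Cc1cc(Cl)ccc1OCC(C)C`) has only a limit, > 3.7, and no number, so its exact place is open. The step to it is a number at least 0.60 log units higher from compound 2 to compound 3 (beyond the scatter).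

Compound 4 (`Cc1cc(NC(=O)OC(C)C)nn1Cc1cc(Cl)ccc1OCC(C)C`) changes compound 3 in one place: isopropoxy in place of cyclohexyl on a carbonyl carbon. This puts isopropoxy in place of cyclohexyl on a carbonyl carbon.

Going by the values given here, two measured steps bear on this change. The step of a number at least 0.60 log units higher from compound 2 to compound 3 (beyond the scatter) concerns the same part of the molecule and shows that changes there can move the read-out beyond the scatter. The step of a number 0.60 log units lower from compound 1 to compound 2 (beyond the scatter) is the one measured case of an isopropyl group replacing a ring, and it is modest and downward. A similar modest fall is expected here, a step that the limit leaves unreadable from compound 3 to compound 4. The size stays loose, since the starting point is a limit, and another report as a limit remains possible. For compound 4 the estimate is 3.9, with an expected range from 3.4 to 4.4.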

Compound 4, distribution coefficient: > 3.7
Compound 4 ended at the assay's limit; the forecaster's own chance of this, stated with the estimate: 55%; the middle value is on the limit's open side.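

In this assay compound 4 has only a limit, > 3.7, and no number. Isopropoxy on the carbonyl carbon, with no ring and one hydrogen-bond acceptor, leaves compound 4 at the same limit as compound 3 with its cyclohexyl, so removing the ring from this group does not bring the read-out to a number: the limit of > 3.7 in this assay, at which 2 of the 4 values shown sit. With (isopropoxycarbonyl)amino in place of carbamoyl on the aromatic carbon, the result is a number at least 0.60 log units higher from compound 2 to compound 4 (beyond the scatter), so the rise at this position is no longer tied to (cyclohexylcarbonyl)amino alone.

The step from compound 3 to compound 4 cannot be read, and the two groups on the carbonyl carbon stay unranked. From the compounds shown here alone, whether methyl, a dimethylamino group or a chain ending in a carboxylic acid on that carbonyl carbon would give a number in this assay stays open.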